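The source may report more compounds than this note shows. Statements on the series, on what has been measured and on what is new or still open speak of the compounds shown alone.

Measured so far in an ADME assay on L02 cells (Homo sapiens) for cytotoxicity, read by MTT assay, with a stated time of 24 h; on this read-out higher numbers stand for weaker inhibition and lower numbers for stronger inhibition:
- compound 1 `O=C1/C(=C/c2ccncc2)CN(S(=O)(=O)c2ccccc2)C/C1=C\c1ccccc1C(F)(F)F` at 12300 nM
- compound 2 `O=C1/C(=C/c2ccncc2)CN(S(=O)(=O)c2ccc(F)cc2)C/C1=C\c1ccccc1C(F)(F)F` at 12900 nM

Compound 2 stands within the scatter of compound 1. Compound 3 `CC(=O)Nc1ccc(S(=O)(=O)N2C/C(=C\c3ccncc3)C(=O)/C(=C/c3ccccc3C(F)(F)F)C2)cc1` carries acetamido in place of fluoro on an aromatic carbon para to a large group. Among the measured compounds shown here, the only measured step bearing on this is a 1.0-fold higher number from compound 1 to compound 2 (0.02 log units; within the scatter) for fluoro in place of hydrogen on that same carbon. For the measured compounds named here, no step beyond the scatter is therefore expected in this assay, although no measured compound carries acetamido and the range stays wide. The expected move is a 1.1-fold lower number from compound 2 to compound 3 (0.03 log units; within the scatter) in size. Compound 3 is estimated at 12000 nM with a range of 5000 nM to 30000 nM as the working expectation.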

Compound 3, half-maximal inhibitory concentration: 10100 nM
Beside the measured number, compound 3's estimate is 1.2-fold (0.07 log units) above it; measured number inside the range.
By their numbers in this assay, from the lowest: compounds 3, 1 and 2 (each within the scatter of the next).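

With a 1.3-fold lower number from compound 2 to compound 3 (0.11 log units; within the scatter) and a 1.2-fold lower number from compound 1 to compound 3 (0.09 log units; within the scatter) in this assay the change at this aromatic carbon, para to a large group, stays within the scatter even with acetamido, which brings a hydrogen-bond donor and acceptor that fluoro lacks. Hydrogen, fluoro and acetamido at this carbon are therefore not separated by this read-out, whereas the earlier compounds covered only hydrogen and fluoro. No supporting evidence bears on this result. As far as these compounds go, whether an amine, a carboxylic acid or a longer chain at this carbon would give a step beyond the scatter remains open. Also open, from the compounds shown here alone, is how changes elsewhere on the shared core would read here.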